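Replacing the boron-bearing ring group of compound 2

The source may hold more compounds than are shown below. What is called first, only, known or untested is meant among the compounds shown, and "the series" means these compounds.

In a functional assay on A549 cells (Homo sapiens) for antiproliferative activity, read by fluorescence and resazurin assay, with a stated time of 72 h (on this read-out higher numbers stand for weaker inhibition and lower numbers for stronger inhibition), compound 1 `CC1(C)OB(c2ccc(CONC(=O)/C=C/c3cccc(S(=O)(=O)Nc4ccccc4)c3)cc2)OC1(C)C` gives 453 nM and compound 2 `CC1(C)OB(c2cccc(CONC(=O)/C=C/c3cccc(S(=O)(=O)Nc4ccccc4)c3)c2)OC1(C)C` gives 3600 nM, the higher of the two numbers, with a gap beyond the scatter. Compound 3 `O=C(/C=C/c1cccc(S(=O)(=O)Nc2ccccc2)c1)NOCc1cccc(B(O)O)c1` keeps the rest of compound 2 and changes on an aromatic carbon, meta to a large group: a group of 3 heavy atoms (1 boron, 2 oxygen; no ring) in place of a group of 9 heavy atoms (6 carbon, 1 boron, 2 oxygen; one five-membered non-aromatic ring with 3 hetero atoms), on an aromatic carbon. Within the data shown here, no measured pair shows this change, so no shift beyond the scatter is expected in this assay, with only a slight lean toward stronger inhibition. The estimated step is a 1.4-fold lower number from compound 2 to compound 3 (0.16 log units; within the scatter) as the expected size. For compound 3 the expected value is 2500 nM, with an estimated range from 800 nM to 8000 nM.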

Compound 3, half-maximal inhibitory concentration: 6580 nM
The estimate for compound 3 lay 2.6-fold (0.42 log units) below the measured number, and the stated range covers the measured number.
By their numbers in this assay, from the lowest: compound 1; then compounds 2 and 3 (each within the scatter of the next).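

In this assay, placing the group of 3 heavy atoms (1 boron, 2 oxygen; no ring) on this aromatic carbon instead of the group of 9 heavy atoms gives a 1.8-fold higher number from compound 2 to compound 3 (0.26 log units; within the scatter) and so stays within the scatter. At this place, the five-membered non-aromatic ring can thus be given up, and the 2 hydrogen-bond donors brought in, without a shift the assay can separate from scatter. Nothing at hand explains this result.

The compounds shown leave open whether the same change would behave alike on the ring of compound 1. They also leave open how a carboxylic acid or an amine would fare on this carbon.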